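Hydrazide series: cytotoxicity working notes on four compounds

A few compounds are considered here, and "the series" means these few. Any claim that something is new, unique, unknown or untested is made for them only; others in the source may bear on it.

compound 1 `COc1cccc(C(=O)NNc2c(Br)cccc2Br)c1` — > 100000 nM
compound 2 `N#Cc1ccc(C(=O)NNc2c(Br)cccc2Br)cc1` — > 100000 nM
compound 3 `CCOc1ccc(C(=O)NNc2ccccc2Br)cc1` — > 100000 nM

Three compounds have been run in a toxicity assay on MDCK cells (Canis lupus familiaris) for cytotoxicity, read by CCK-8 assay, with a stated time of 48 h; on this read-out lower numbers stand for higher toxicity in this test and higher numbers for lower toxicity in this test. Compound 1 gives > 100000 nM, which is a limit of the assay and not a number. Compound 2 gives > 100000 nM, again a limit of the assay. Compound 3 gives > 100000 nM, also a limit. Compound 2 therefore stands nowhere in particular within the measured set: it sits at the limit of > 100000 nM in this assay, at which 3 of the 3 values shown sit, and no ordering among compounds 1, 2 and 3 can be read from these values.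

Compound 4 `O=C(NNc1c(Br)cccc1Br)c1ccc(O)cc1` is not yet measured. It differs from compound 2 in one place, (hydroxy in place of cyano on an aromatic carbon).

Among the compounds with values here, no step between measured compounds is available to guide the expectation, and none of the three measured values escaped the limit. The expected step in this assay is a number no higher from compound 2 to compound 4 (the limit leaves the size open), which is no change beyond the usual scatter, in either direction. Compound 4 is therefore expected to give about 100000 nM in this assay, with an estimated range from 50000 nM to 300000 nM, and most likely to be reported again only as a limit.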

Compound 4, half-maximal cytotoxic concentration: > 100000 nM
Compound 4: only a limit was reported (the forecaster's own chance of this, stated with the estimate: 85%); the middle value lies on the limit itself.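

No step can be read from compound 2 to compound 4 in this assay, since both values are limits of the assay and not numbers: the limit of > 100000 nM in this assay, at which 4 of the 4 values shown sit.

The compounds shown leave open how toxic any of them is in this assay and whether hydroxy in place of cyano alters that.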